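Replacing 3,5-dichlorophenyl with 1H-indazol-6-yl

The source may hold more compounds than are shown below. What is called first, only, known or untested is meant among the compounds shown, and "the series" means these compounds.

Measured compounds:
- compound 1 `CC(C)CNc1ccc(NC(=O)c2cc(Cl)ccc2O)c(Cl)c1` gives 60000 nM
- compound 2 `O=C(Nc1ccc(NCc2ccc(F)cc2)cc1Cl)c1cc(Cl)ccc1O` gives 54400 nM
- compound 3 `O=C(Nc1ccc(NCc2cc(Cl)cc(Cl)c2)cc1Cl)c1cc(Cl)ccc1O` gives 13300 nM

All three values come from an ADME assay on A549 cells (Homo sapiens) for cytotoxicity, read by resazurin assay, with a stated time of 48 h (on this read-out higher numbers stand for lower toxicity in this test and lower numbers for higher toxicity in this test), and, among them, compound 3 has the lowest number at 13300 nM with both of its steps beyond the scatter. The next compound to be read is compound 4 `O=C(Nc1ccc(NCc2ccc3cn[nH]c3c2)cc1Cl)c1cc(Cl)ccc1O` and its change is as follows (1H-indazol-6-yl in place of 3,5-dichlorophenyl on a saturated chain carbon bound to a nitrogen on an aromatic ring).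

Going by the values given here, three measured steps concern this same place. Replacing isopropyl with 4-fluorophenyl gives a 1.1-fold lower number from compound 1 to compound 2 (0.04 log units; within the scatter) in this assay and so separates nothing. The two steps into 3,5-dichlorophenyl are modest, namely a 4.5-fold lower number from compound 1 to compound 3 (0.65 log units; beyond the scatter) and a 4.1-fold lower number from compound 2 to compound 3 (0.61 log units; beyond the scatter) in the same read-out. Among these three compounds, only the one carrying 3,5-dichlorophenyl stands apart. Among the compounds with values here, no measured compound carries 1H-indazol-6-yl, so the size of the change rests on these steps alone and remains uncertain. Losing 3,5-dichlorophenyl is expected to give a modest move to a higher number, returning towards compound 2 at 54400 nM without a firm claim of reaching it. The expected step is a 2.6-fold higher number from compound 3 to compound 4 (0.42 log units; beyond the scatter) in this read-out. The estimate for compound 4 is 35000 nM with an expected range of 13000 nM to 85000 nM in this assay here.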

Compound 4, half-maximal cytotoxic concentration: 45300 nM
Compound 4: middle estimate off by 1.3-fold (0.11 log units), on the low side; low and high end bracket the measured number.
By their numbers in this assay, from the lowest: compound 3; then compounds 4, 2 and 1 (each within the scatter of the next).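

Working notes on the group on the saturated chain carbon bound to a nitrogen on an aromatic ring: in this assay, a 3.4-fold higher number from compound 3 to compound 4 (0.53 log units; beyond the scatter) shows that the low number of compound 3 is not kept when 3,5-dichlorophenyl gives way to 1H-indazol-6-yl, although the entering group also carries a six-membered aromatic ring of carbon only. The other two steps, a 1.2-fold lower number from compound 2 to compound 4 (0.08 log units; within the scatter) and a 1.3-fold lower number from compound 1 to compound 4 (0.12 log units; within the scatter), both lie within the scatter, so 1H-indazol-6-yl, 4-fluorophenyl and isopropyl are not separated here, and among the four compounds only compound 3 stands apart. Nothing available here bears on what sets 3,5-dichlorophenyl apart from the other three groups.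

Going by these compounds, it stays open whether a ring with a single chlorine, such as 4-chlorophenyl, or a ring with two other substituents, such as 3,5-dimethylphenyl, would follow compound 3 or stay with compounds 1, 2 and 4. On these data alone, it is also open whether a piperidine or a carboxylic acid at this place would depart from those three compounds in either direction.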